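Silicon substituent swap in a squalene monooxygenase series

This account rests on a few compounds, and the source may have more. Where it says the series, first, only, none or still open, it means among the compounds named here.

Compound 3 `CCN(C/C=C/C#CC(C)(C)C)Cc1cccc(OC[Si](C)(C)c2ccc(C(=O)C(F)(F)F)cc2)c1` holds the highest number of the three measured compounds in a functional assay on liver (Sus scrofa) for inhibition of squalene monooxygenase (Homo sapiens), using microsomes (a lower number here means a stronger inhibitor, a higher number a weaker inhibitor), giving 5000 nM. Compound 1 `CCN(C/C=C/C#CC(C)(C)C)Cc1cccc(OC[Si](C)(C)c2ccc(F)cc2)c1` gives 60 nM and compound 2 `CCN(C/C=C/C#CC(C)(C)C)Cc1cccc(OC[Si](C)(C)c2ccc(Br)cc2)c1` gives 210 nM. Compound 4 `CCN(C/C=C/C#CC(C)(C)C)Cc1cccc(OC[Si](C)(C)C2CCCCC2)c1` differs from compound 3 by cyclohexyl in place of 4-((trifluoromethyl)carbonyl)phenyl on a silicon. Among the measured compounds shown here, the steps that bear on this change are an 83-fold higher number from compound 1 to compound 3 (1.92 log units; beyond the scatter) and a 24-fold higher number from compound 2 to compound 3 (1.38 log units; beyond the scatter), both large, where the group now leaving was the one entering; a 3.5-fold higher number from compound 1 to compound 2 (0.54 log units; beyond the scatter) was modest. For the measured compounds named here, no measured step covers the cyclohexyl that enters, so the size of the drop is uncertain. The expected step is a 33-fold lower number from compound 3 to compound 4 (1.52 log units; beyond the scatter), a decrease beyond the scatter. Compound 4 is estimated at 150 nM, with a range from 40 nM to 600 nM.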

Compound 4, half-maximal inhibitory concentration: 20000 nM
The estimate for compound 4 lay 130-fold (2.12 log units) below the measured number; measured number outside the range, above it.
By their numbers in this assay, from the lowest: compound 1; then compound 2; then compound 3; then compound 4.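

In this assay, cyclohexyl on the silicon gives the highest number of the four compounds: a 4.0-fold higher number from compound 3 to compound 4 (0.60 log units; beyond the scatter), a 95-fold higher number from compound 2 to compound 4 (1.98 log units; beyond the scatter) and a 330-fold higher number from compound 1 to compound 4 (2.52 log units; beyond the scatter). Compound 4 is the only compound shown without an aromatic ring at this position, and it falls behind even the 4-((trifluoromethyl)carbonyl)phenyl group of compound 3, so the loss at this silicon is not confined to the phenyl substituents compared so far. No measured evidence accounts for this result. Still open, from the compounds shown here alone, is how an unsubstituted phenyl, a 4-aminophenyl or an open hexyl chain on this silicon would compare.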